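Chloro added to the phenyl ring of compound 1

The compounds below may be only part of what the source reports. "The series", "measured", "known", "first", "only" and "open" are said of these compounds alone.

Compound 1 `N=c1c(C(N)=O)cc(Cl)cn1Cc1ccccc1` gives the lowest number of the two measured in an assay on CHO-K1 cells for displacement of a labelled ligand from Alpha-1D adrenergic receptor (Homo sapiens), read by scintillation counting, with a stated time of 60 min (on this read-out higher numbers stand for weaker inhibition and lower numbers for stronger inhibition), at 30 nM. Within the data shown here, its nearest neighbour is compound 2 `N=c1c(C(N)=O)cc(Cl)cn1Cc1ccco1`, which in this assay gives 160 nM; the only measured step, a 5.3-fold higher number from compound 1 to compound 2 (0.73 log units; beyond the scatter), replaces the whole aryl group rather than decorating it. Compound 3 `N=c1c(C(N)=O)cc(Cl)cn1Cc1ccc(Cl)cc1` differs from compound 1 by chloro in place of hydrogen on an aromatic carbon, on the phenyl that compound 2 lacks. Among the measured compounds shown here, no measured step touches a substituent on that ring, so the step from compound 1 to compound 2 bears on the new change only in showing that alteration at this end of the molecule produced a modest shift. With nothing closer to go on, a change within the scatter is expected for compound 3 in this assay, giving no change at the digits printed from compound 1 to compound 3 (within the scatter). The estimate for compound 3 is 30 nM, with a range from 10 nM to 90 nM.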

Compound 3, inhibition constant: 23 nM
The estimate for compound 3 lay 1.3-fold (0.12 log units) above the measured number; measured number inside the range.
By their numbers in this assay, from the lowest: compounds 3 and 1 (each within the scatter of the next); then compound 2.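

In this assay, chloro in place of hydrogen on an aromatic carbon, para to a large group, gives a 1.3-fold lower number from compound 1 to compound 3 (0.12 log units; within the scatter) and so stays within the scatter. Among these compounds, the phenyl of compound 1 therefore takes this single added chlorine at this place without a shift beyond the scatter, whereas the only earlier step, a 5.3-fold higher number from compound 1 to compound 2 (0.73 log units; beyond the scatter), came from replacing the whole aryl group. No supporting data here explain why the number holds at this place.

Open, on these data alone, is whether this place also accepts a methoxy group, an amine or a carboxylic acid, or whether the flat result holds only for chloro. Also open, as far as these compounds go, is whether chloro elsewhere on the phenyl ring, or on the furan-2-yl group of compound 2, would behave the same way.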